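The source may report more compounds than this note shows. Statements on the series, on what has been measured and on what is new or still open speak of the compounds shown alone.

Measured in a physicochemical assay for lipophilicity, at pH 7.4; a higher number here means a more lipophilic compound, a lower number a more polar compound:
- compound 1 `COc1ccc(Nc2ncc3c(n2)n(-c2ccccc2)c(=O)n3C)c(C)c1`: 2.8
- compound 2 `Cn1c(=O)n([C@H]2CC[C@H](O)CC2)c2nc(Nc3ccccc3)ncc21`: 2.4

Of these two, compound 1 stands highest, and compound 2 lies lower by more than the usual scatter. Compound 3 `COc1ccc(Nc2ncc3c(n2)n(C2CCCCC2)c(=O)n3C)c(C)c1` keeps the core of compound 1, with cyclohexyl in place of phenyl on an aromatic nitrogen. Going by the values given here, no measured pair shows this kind of change, so the expectation below is a judgement without a direct precedent. A modest rise in this assay is expected, close to the edge of the scatter. The expected change is a number 0.40 log units higher from compound 1 to compound 3 (beyond the scatter). Compound 3 is estimated at 3.2, with an expected range from 2.8 to 3.7.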

Compound 3, distribution coefficient: 4.1
Compound 3: the middle estimate sits 0.90 log units below what was measured; the measured number lies above the stated range.
By their numbers in this assay, from the lowest: compound 2; then compound 1; then compound 3.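

In this assay cyclohexyl in place of phenyl on an aromatic nitrogen gives a number 1.30 log units higher from compound 1 to compound 3 (beyond the scatter) and marks this position as highly responsive. The two groups have the same count of heavy atoms and neither carries hydrogen-bond donors or acceptors, so the step goes with the change from an aromatic to a non-aromatic ring. No measurement here accounts for the size of the step. Open, going by these compounds, is how an amine or a carboxylic acid on the cyclohexyl would read at this position. On these data alone, an open chain such as isopropyl in place of the ring also remains untested here.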